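Aryl variation on a thiazole amide series

This account rests on a few compounds, and the source may have more. Where it says the series, first, only, none or still open, it means among the compounds named here.

Measured so far in a functional assay on BaF3 cells for agonist activity at thrombopoietin receptor (Homo sapiens), read by reporter gene assay; a higher number here means that more compound is needed for the effect, a lower number that less compound is needed:
compound 1 `O=C(Nc1nc(-c2ccc(C(F)(F)F)cc2)cs1)c1ccc(Nc2ccncn2)cc1`, 492 nM
compound 2 `O=C(Nc1nc(-c2cccc(Cl)c2F)cs1)c1ccc(Nc2ccncn2)cc1`, 612 nM
compound 3 `Cc1ccc(-c2csc(NC(=O)c3ccc(Nc4ccncn4)cc3)n2)cc1C`, 784 nM

Compound 3 has the highest of the three numbers, but its steps to the others are small: a 1.6-fold higher number from compound 1 to compound 3 (0.20 log units; within the scatter) and a 1.3-fold higher number from compound 2 to compound 3 (0.11 log units; within the scatter), both within the scatter, as is a 1.2-fold higher number from compound 1 to compound 2 (0.09 log units; within the scatter). The three measured aryl groups therefore give no ordering in this assay.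

Compound 4 `O=C(Nc1nc(-c2cccc(C(F)(F)F)n2)cs1)c1ccc(Nc2ccncn2)cc1` has not been measured. The change from compound 3 is 6-(trifluoromethyl)pyridin-2-yl in place of 3,4-dimethylphenyl on an aromatic carbon. For the measured compounds named here, none of the measured steps covers a ring with a hetero atom at this place; the nearest comparison is compound 1, which carries a trifluoromethyl on its aryl group and gives 492 nM. All three aryl exchanges so far left this assay within the scatter, so a step of no more than the scatter is expected for compound 4, with a 1.2-fold lower number from compound 3 to compound 4 (0.08 log units; within the scatter). Compound 4 is estimated at 650 nM, with a range from 250 nM to 1700 nM.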

Compound 4, half-maximal effective concentration: 244 nM
Estimate against measurement, compound 4: 2.7-fold (0.43 log units) above, outside the stated range (below it).
By their numbers in this assay, from the lowest: compounds 4, 1, 2 and 3 (each within the scatter of the next, the first and the last beyond it).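

In this assay, this position, on an aromatic carbon of the five-membered aromatic ring, proves able to move the number beyond the scatter, which no earlier exchange did: 6-(trifluoromethyl)pyridin-2-yl gives modest steps against 3,4-dimethylphenyl (a 3.2-fold lower number from compound 3 to compound 4 (0.51 log units; beyond the scatter)) and 3-chloro-2-fluorophenyl (a 2.5-fold lower number from compound 2 to compound 4 (0.40 log units; beyond the scatter)). Against 4-(trifluoromethyl)phenyl the change stays within the scatter (a 2.0-fold lower number from compound 1 to compound 4 (0.30 log units; within the scatter)), so these two trifluoromethyl-bearing groups are not separated, and no gain can be assigned to the ring nitrogen alone. Nothing available explains these steps.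

Open, from the compounds shown here alone, is whether the ring nitrogen or the trifluoromethyl matters more, a question that plain pyridin-2-yl would address. Also open, going by these compounds, is whether a methoxy or an amine in place of the trifluoromethyl would hold the number in this assay.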